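Double-bond geometry at a benzylidene hydantoin core

The source may report more compounds than this note shows. Statements on the series, on what has been measured and on what is new or still open speak of the compounds shown alone.

Compound 1 `CCCCN1C(=O)NC(=O)/C1=C/c1ccccc1`: 18%
Compound 2 `O=C1NC(=O)N(c2ccccc2)/C1=C\c1ccccc1`: 26%
Compound 3 `CN1C(=O)NC(=O)/C1=C\c1ccccc1`: 5.7%

In a functional assay on A549 cells (Homo sapiens) for antiproliferative activity, read by trypan blue exclusion, with a stated time of 72 h, tested at 20 uM (a higher number here means more inhibition at the concentration tested (going by the name of the read-out), a lower number less inhibition), compound 3 gives the lowest of the three numbers; compound 1 lies closer to it and compound 2 furthest, both gaps beyond the scatter. Going by the values given here, the one measured step, a number 8 percentage points higher from compound 1 to compound 2 (within the scatter), swaps the group on the ring nitrogen and lies within the scatter. Compound 4 `CN1C(=O)NC(=O)/C1=C/c1ccccc1` differs from compound 3 only as follows: the two compounds have the same atoms and bonds and differ only in configuration as drawn: 1 of 1 stereo elements differ; a double bond is drawn E in compound 3 and Z in compound 4. Among the compounds with values here, no measured pair changes the double-bond geometry alone, so nothing in this set bears directly on the step. Compound 4 is therefore expected to stay near compound 3, an expected step of a number 4.3 percentage points higher from compound 3 to compound 4 (within the scatter) within the scatter. The estimate for compound 4 is 10%, from 0% to 25%.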

Compound 4, a percentage reported as inhibition, at one concentration (the size of the read-out at that concentration, not a potency): 16%
Beside the measured number, compound 4's estimate is 6 percentage points below it; low and high end bracket the measured number.
By their numbers in this assay, from the lowest: compound 3; then compounds 4, 1 and 2 (each within the scatter of the next).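

In this assay the double-bond geometry alone shifts the read-out, with a number 10.3 percentage points higher from compound 3 to compound 4 (beyond the scatter), and nothing else separates the pair: the fact that compounds 3 and 4 differ only in the configuration as drawn. Group changes on the ring nitrogen stay within the scatter, with a number 10 percentage points lower from compound 2 to compound 4 (within the scatter) for methyl in place of phenyl and a number 2 percentage points lower from compound 1 to compound 4 (within the scatter) for methyl in place of butyl.

As far as these compounds go, whether the geometry step carries over to compounds with butyl or phenyl on that nitrogen stays open. So does the effect of an amine or a carboxylic acid on the benzylidene phenyl ring.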